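Swapping a nitrophenyl for a methylsulfanylphenyl on the urea

The source may hold more compounds than are shown below. What is called first, only, known or untested is meant among the compounds shown, and "the series" means these compounds.

Measured so far:
compound 1 `O=C(Nc1cccc([N+](=O)[O-])c1)N[C@H]1CC[C@H](Oc2ccc(F)cc2)CC1` gives 6700 nM
compound 2 `O=C(Nc1cccc(C(F)(F)F)c1)N[C@H]1CC[C@H](Oc2ccccc2F)CC1` gives 2450 nM

Both were tested in a functional assay on CRL2813 cells (Homo sapiens) for cytotoxicity, read by sulforhodamine B assay, with a stated time of 5 days; on this read-out lower numbers stand for stronger inhibition and higher numbers for weaker inhibition. Compound 1 holds the higher of the two numbers, so it is the weaker of the pair, and the gap to compound 2 lies beyond the usual scatter. Compound 3 `CSc1ccccc1NC(=O)N[C@H]1CC[C@H](Oc2ccc(F)cc2)CC1` has not yet been measured; it differs from compound 1 in one place: 2-(methylsulfanyl)phenyl in place of 3-nitrophenyl on an amide-type nitrogen. Going by the values given here, no measured pair shows this kind of change, so the expected step of a 1.7-fold lower number from compound 1 to compound 3 (0.22 log units; within the scatter) is small, a modest move toward a lower number that may not exceed the scatter. Compound 3 is estimated at 4000 nM, with a range from 1500 nM to 12000 nM.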

Compound 3, half-maximal inhibitory concentration: > 20000 nM
Compound 3: no number, only a limit; the forecaster's own chance of this, stated with the estimate: 5%; middle value at least 5.0-fold (0.69 log units) away from the limit.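

In this assay, the group on the amide-type nitrogen proves able to shift the result: 2-(methylsulfanyl)phenyl in place of 3-nitrophenyl gives an at least 2.9-fold higher number from compound 1 to compound 3 (0.47 log units; beyond the scatter). Compound 3 has no number here, only a limit, so the full size of this step stays unknown: the limit of > 20000 nM in this assay, at which 1 of the 3 values shown sits.

This single change replaces both the group and its place on the ring, and the compounds shown cannot separate those two effects. Where a plain phenyl or a methoxyphenyl on that nitrogen would fall also remains open.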